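Thiophen-2-yl for Phenyl: Working Note on Compound 4

This account rests on a few compounds, and the source may have more. Where it says the series, first, only, none or still open, it means among the compounds named here.

Compound 3 `Oc1ccc(-c2cc(-c3ccccc3)nc(-c3ccccc3Cl)c2)cc1` serves as the reference in this set. In a functional assay on HCT-15 cells (Homo sapiens) for cytotoxicity, read by CCK-8 assay and cell counting, with a stated time of 2 days (on this read-out higher numbers stand for weaker inhibition and lower numbers for stronger inhibition), compound 3 gives 4990 nM, the lowest of the two numbers in hand. Compound 2 `Oc1cccc(-c2cc(-c3ccc(Cl)cc3)nc(-c3ccco3)c2)c1` gives 10200 nM in this assay, a gap that lies beyond the usual scatter. For compound 1 `Oc1ccc(-c2cc(-c3cccnc3)nc(-c3ccccc3Cl)c2)cc1` the entry in this assay reads "not determined" (no result reported), so no number is in hand for it. Among the compounds with values here, no two measured compounds differ in a single place, so there is no calibrated step to lean on.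

The unmeasured compound 4 `Oc1ccc(-c2cc(-c3cccs3)nc(-c3ccccc3Cl)c2)cc1` differs from compound 3 in one place: thiophen-2-yl in place of phenyl on an aromatic carbon. The new group sits on an aromatic carbon next to the ring nitrogen, meta to the 2-chlorophenyl group and meta to the 4-hydroxyphenyl group; everything else in compound 3 is retained.

Within the data shown here, with no precedent for this exchange among the measured compounds, the expectation is a step in this assay of no clear direction and not beyond the scatter, because compound 3 at 4990 nM is the only anchor. Compound 4 is therefore estimated at 4500 nM, with a range of 1500 nM to 13000 nM. The expected step is a 1.1-fold lower number from compound 3 to compound 4 (0.04 log units; within the scatter).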

Compound 4, half-maximal inhibitory concentration: 5430 nM
Compound 4: the middle estimate sits 1.2-fold (0.08 log units) below what was measured; the range from low to high includes it.
By their numbers in this assay, from the lowest: compounds 3, 4 and 2 (each within the scatter of the next, the first and the last beyond it).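

In this assay, within the data shown here, the exchange of phenyl for thiophen-2-yl on the aromatic carbon next to the ring nitrogen gives a 1.1-fold higher number from compound 3 to compound 4 (0.04 log units; within the scatter) and so supplies the first single-place step. Among these compounds, at this position, with the 2-chlorophenyl and 4-hydroxyphenyl groups retained, a five-membered aromatic ring with 1 hetero atom can therefore stand in place of the six-membered carbon ring while the two numbers stay within the scatter of each other, which the earlier compounds, none of them a single-place pair, could not show. Nothing measured here bears on why the two groups read alike.

As far as these compounds go, whether this carbon accepts groups of other kinds, such as an amine, a carboxylic acid or a longer alkyl chain, stays open, and one exchange between two aromatic rings sets no general rule for the position. Among the compounds shown here, compound 1 also differs from compound 3 at this carbon, but compound 1 stands at "not determined" (no result reported) in this assay and so adds no second step at this position.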